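This account rests on a few compounds, and the source may have more. Where it says the series, first, only, none or still open, it means among the compounds named here.

Measured so far in an in vitro ADME assay on microsomes from liver (Homo sapiens) for metabolic stability, tested at 1 uM; a higher number here means that the compound lasts longer, a lower number that the compound disappears faster:

- compound 1 `Cc1ccc(CN2C(=O)C(C3=NS(=O)(=O)c4cc(NS(C)(=O)=O)ccc4N3)=C(O)[C@@H]3[C@H]4CC[C@H](C4)[C@@H]32)cc1F`: > 1 h
- compound 2 `CS(=O)(=O)Nc1ccc2c(c1)S(=O)(=O)N=C(C1=C(O)[C@@H]3[C@@H]4CC[C@@H](C4)[C@@H]3N(Cc3ccccc3)C1=O)N2`: > 1 h

Compound 2 reads > 1 h, which is a limit of the assay and not a number. Compound 1 reads > 1 h, and this too is a limit. Among the measured compounds shown here, neither compound can be ranked against the other, and the series so far stands at a single point: the limit of > 1 h in this assay, at which 2 of the 2 values shown sit.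

Compound 3 `CS(=O)(=O)Nc1ccc2c(c1)S(=O)(=O)N=C(C1=C(O)[C@@H]3[C@@H]4CC[C@@H](C4)[C@@H]3N(Cc3ccc(F)c(F)c3F)C1=O)N2` differs from compound 2 in one place: 2,3,4-trifluorophenyl in place of phenyl on a saturated chain carbon bound to an amide-type nitrogen in a ring. The change sits on a saturated chain carbon bound to an amide-type nitrogen in a ring, where 2,3,4-trifluorophenyl takes the place of phenyl.

For the measured compounds named here, no measured step shows what such a change does in this assay, so the only guide is the limit of > 1 h in this assay, at which 2 of the 2 values shown sit. No shift beyond the usual scatter is expected, and the assay may well report only a limit again. The estimated step is a step that the limit leaves unreadable from compound 2 to compound 3. For compound 3 the estimated half-life is 1.5 h, with an expected range of 1 h to 3 h.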

Compound 3, half-life: > 1 h
Compound 3 ended at the assay's limit; the forecaster's own chance of this, stated with the estimate: 85%; the middle value is on the limit's open side.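

Among the compounds shown here, compound 2 and compound 3 both end at a limit in this assay and not at a number, so the change from phenyl to 2,3,4-trifluorophenyl gives no step that can be read. How long compound 1, compound 2 and compound 3 really last, and whether they differ at all, stays open, because the series still stands at one point: the limit of > 1 h in this assay, at which 3 of the 3 values shown sit.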